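The source may hold more compounds than are shown below. What is called first, only, known or untested is meant among the compounds shown, and "the series" means these compounds.

Working notes on the series. In a functional assay on SUP-B15 cells (Homo sapiens) for antiproliferative activity, with a stated time of 72 h (on this read-out higher numbers stand for an effect only at larger amounts of compound and lower numbers for an effect already at smaller amounts), compound 1 `COc1ccc(-c2cc(=O)c3c(OC)cc(OC)cc3n2C)cc1` gives 28000 nM. In this assay compound 2 `COc1ccc(-c2cc(=O)c3c(OC)cc(OC)cc3n2Cc2ccccc2)cc1` gives only a limit, > 34400 nM. In this assay compound 3 `COC(=O)c1cc(=O)c2cc(N)ccc2[nH]1` likewise gives only a limit, > 67200 nM. Compound 2 thus stands at a limit, as does compound 3, and only compound 1 carries a number. Going by the values given here, the single measured step is an at least 1.2-fold higher number from compound 1 to compound 2 (0.08 log units; that floor lies within the scatter). Compound 4 `COc1ccc(-c2cc(=O)c3c(OC)cc(OC)cc3n2S(=O)(=O)c2ccc(C=O)cc2)cc1` differs from compound 2 by (4-formylphenyl)sulfonyl in place of benzyl on an aromatic nitrogen. Among the compounds with values here, the measured step bears on it only in that it also changes the group on that aromatic nitrogen and ends at a limit; no measured step covers a sulfonyl at this position. Compound 4 is therefore expected to stay near the limit, a step that the limit leaves unreadable from compound 2 to compound 4. The estimate for compound 4 is 40000 nM, within 15000 nM to 100000 nM.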

Compound 4, half-maximal effective concentration: > 34400 nM
Compound 4: a limit, no number; the forecaster's own chance of this, stated with the estimate: 70%; the middle value does not contradict the limit.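

Swapping methyl for (4-formylphenyl)sulfonyl on the aromatic nitrogen gives, in this assay, an at least 1.2-fold higher number from compound 1 to compound 4 (0.08 log units; that floor lies within the scatter). Among the compounds shown, only compound 1, with methyl on this nitrogen, carries a number, while benzyl and (4-formylphenyl)sulfonyl both end at a limit. Compound 2 and compound 4 share one limit, and the step between them cannot be read: the limit of > 34400 nM in this assay, at which 2 of the 4 values shown sit.

The compounds shown leave open whether an ethyl group or a longer chain ending in an amine on this nitrogen would give a measurable number. As far as these compounds go, the part played by the formyl group also stays open, with no plain phenylsulfonyl among them.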